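This account rests on a few compounds, and the source may have more. Where it says the series, first, only, none or still open, it means among the compounds named here.

Measured compounds:
Compound 1 `CCOC(=O)Cn1ncc2c(Nc3ccc(NS(=O)(=O)c4ccc([N+](=O)[O-])cc4)cc3)ncnc21` — in a functional assay on cells (Homo sapiens) for inhibition, read by MTT assay, with a stated time of 72 h (on this read-out lower numbers stand for stronger inhibition and higher numbers for weaker inhibition), compound 1 gives > 64 ug/mL, which is a limit of the assay and not a number.
Compound 2 `O=C(O)Cn1ncc2c(Nc3ccc(NS(=O)(=O)c4ccc([N+](=O)[O-])cc4)cc3)ncnc21` — in this assay compound 2 gives > 100 ug/mL, again a limit of the assay.
Compound 3 `CC(=O)Nc1ccc(Nc2ncnc3c2cnn3CC(=O)O)cc1` — in this assay compound 3 gives > 64 ug/mL, also a limit of the assay.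

Compound 3 therefore stands at the limit of > 64 ug/mL in this assay, at which 2 of the 3 values shown sit, and compound 2 at the limit of > 100 ug/mL in this assay, at which 1 of the 3 values shown sits. Among the compounds with values here, no measured compound has a readable number, so compound 3 cannot be placed in any order among them. Within the data shown here, the one step between compounds that differ in a single place, a step that the two limits leave unreadable from compound 1 to compound 2, stays unreadable between its two limits.

Compound 4 `O=C(O)Cn1ncc2c(Nc3ccc(NC(=O)c4ccccc4)cc3)ncnc21` differs from compound 3 by phenyl in place of methyl on a carbonyl carbon. Among the measured compounds shown here, none of the measured steps bears on this change, and nothing measured reaches a number at all. The step that the limit leaves unreadable from compound 3 to compound 4 is therefore expected to be of no readable size in this assay, with compound 4 most likely staying at a limit. In this assay compound 4 is expected to give about 80 ug/mL, within a range from 30 ug/mL to 200 ug/mL.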

Compound 4, half-maximal inhibitory concentration: > 100 ug/mL
Compound 4 gave a limit, no number; the forecaster's own chance of this, stated with the estimate: 70%; middle value at least 1.2-fold (0.09 log units) away from the limit.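

In this assay compound 4 gives > 100 ug/mL, a limit of the assay and not a number. Compound 3 also stands at a limit, so no step can be read between compound 3 and compound 4. The compounds shown leave open whether phenyl in place of methyl on a carbonyl carbon changes inhibition at all.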